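Swapping the ring for an open chain on the carbonyl

The source may hold more compounds than are shown below. What is called first, only, known or untested is meant among the compounds shown, and "the series" means these compounds.

Compound 2 `Cc1cc(NC(=O)C2CCOCC2)nn1Cc1cc(Cl)ccc1OCc1ccccc1` is reached from compound 1 `Cc1cc(NC(=O)C2CCCC2)nn1Cc1cc(Cl)ccc1OCc1ccccc1` by the step of a number at least 0.20 log units higher from compound 1 to compound 2 (that floor lies within the scatter) in a physicochemical assay for lipophilicity, at pH 7.4; on this read-out higher numbers stand for higher lipophilicity and lower numbers for lower lipophilicity. Compound 1 gives 3.5 in this assay. Compound 2 gives only a limit, > 3.7, so its true number is not known; it sits at the limit of > 3.7 in this assay, at which 1 of the 2 values shown sits. Compound 3 `Cc1cc(NC(=O)OCC(C)C)nn1Cc1cc(Cl)ccc1OCc1ccccc1` differs from compound 2 by isobutoxy in place of oxan-4-yl on a carbonyl carbon. For the measured compounds named here, only the step of a number at least 0.20 log units higher from compound 1 to compound 2 (that floor lies within the scatter) touches the same place, and it offers no guide for an open chain, so no step beyond the scatter is expected; the estimated change is a step that the limit leaves unreadable from compound 2 to compound 3. Compound 3 is expected to give 4, between 3.6 and 4.5.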

Compound 3, distribution coefficient: 3.3
Estimate against measurement, compound 3: 0.70 log units above; measured number below the stated range.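

In this assay, isobutoxy in place of oxan-4-yl on this carbonyl carbon brings a number at least 0.40 log units lower from compound 2 to compound 3 (beyond the scatter), so the read-out at this position does respond to this swap. Isobutoxy in place of cyclopentyl brings a number 0.20 log units lower from compound 1 to compound 3 (within the scatter), so this open chain and the cyclopentyl ring cannot be told apart here. The full size of the first step stays unknown because compound 2 gives only a limit: the limit of > 3.7 in this assay, at which 1 of the 3 values shown sits.

Only one open chain appears at this position, so no trend across chains can be read. From the compounds shown here alone, whether a longer chain such as hexyloxy, or an amine, on the same carbonyl carbon would read differently remains open.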